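Swapping the Chlorophenyl Amine for a Methylphenyl Amine

This account rests on a few compounds, and the source may have more. Where it says the series, first, only, none or still open, it means among the compounds named here.

Compound 1, `COc1ccc(/C=C/C(=O)c2sc(Nc3ccc(Cl)cc3)nc2C)cc1`, gives > 25000 nM in a functional assay on BGC-823 cells (Homo sapiens) for cytotoxicity, read by MTT assay; on this read-out lower numbers stand for stronger inhibition and higher numbers for weaker inhibition; this value is a limit of the assay, not a number.
Compound 2, `COc1cccc(/C=C/C(=O)c2sc(Nc3ccc(Cl)cc3)nc2C)c1`, gives > 25000 nM in this assay; this value is likewise a limit, not a number.

Compound 2 thus stands at the upper edge of what this assay can report, the same place where every measured value in this set sits (the limit of > 25000 nM in this assay, at which 2 of the 2 values shown sit). Going by the values given here, the only measured step, a step that the two limits leave unreadable from compound 1 to compound 2, has a limit at both ends and so offers no readable size and no direction.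

Compound 3, `COc1cccc(/C=C/C(=O)c2sc(Nc3ccccc3C)nc2C)c1`, differs from compound 2 by 2-methylphenyl in place of 4-chlorophenyl on a nitrogen on an aromatic ring. Among the compounds with values here, no measured step in this set bears on that change, so there is no measured basis for expecting a move in either direction beyond the scatter. Compound 3 is therefore expected to stay near the same limit, with an estimated 30000 nM and a range of 6000 nM to 120000 nM. That estimate means an expected step that the limit leaves unreadable from compound 2 to compound 3, with a fair chance that only a limit is reported again.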

Compound 3, half-maximal inhibitory concentration: > 25000 nM
Compound 3 was reported as a limit (the forecaster's own chance of this, stated with the estimate: 70%); the middle value is on the limit's open side.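

In this assay, compound 2 and compound 3 both give only a limit, so the swap from 4-chlorophenyl to 2-methylphenyl yields no readable step: the limit of > 25000 nM in this assay, at which 3 of the 3 values shown sit.

The compounds shown leave open how strong any of them really is, and whether this swap changes activity at all.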